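This account rests on a few compounds, and the source may have more. Where it says the series, first, only, none or still open, it means among the compounds named here.

- Compound 1 `Oc1ccc(-c2nc3cc(C(F)(F)F)ccc3[nH]2)cc1`: > 100000 nM (a limit)
- Compound 2 `O=[N+]([O-])c1ccc(-c2nc3cc(C(F)(F)F)ccc3[nH]2)cc1`: 45000 nM

Going by the values given here, in an ADME assay on Vero cells (Chlorocebus sabaeus) for cytotoxicity (on this read-out higher numbers stand for lower toxicity in this test and lower numbers for higher toxicity in this test), compound 2 gives 45000 nM, the only exact number so far. Compound 1 reads > 100000 nM, which is a limit. Compound 3 `Cn1c(-c2ccc([N+](=O)[O-])cc2)nc2cc(C(F)(F)F)ccc21` differs from compound 2 by methyl in place of hydrogen on an aromatic nitrogen. Among the compounds with values here, the one measured step, an at least 2.2-fold lower number from compound 1 to compound 2 (0.34 log units; beyond the scatter), exchanged hydroxy for nitro, not this hydrogen, so it is only a loose guide. Its size is open-ended because of the limit of > 100000 nM in this assay, at which 1 of the 2 values shown sits. No clear change is therefore expected, and the estimated step is a 1.1-fold lower number from compound 2 to compound 3 (0.05 log units; within the scatter). Compound 3 is expected at 40000 nM, within an estimated range of 15000 nM to 100000 nM.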

Compound 3, half-maximal cytotoxic concentration: > 100000 nM
Compound 3 ended at the assay's limit; the forecaster's own chance of this, stated with the estimate: 20%; middle value at least 2.5-fold (0.39 log units) from the limit.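

Methyl in place of hydrogen on the aromatic nitrogen gives an at least 2.2-fold higher number from compound 2 to compound 3 (0.34 log units; beyond the scatter) in this assay. Going by these compounds alone, the earlier step changed hydroxy to nitro, so this is the first sign that the aromatic nitrogen also matters: with the nitro group kept, this one change takes the read-out back to a limit. The full size of the step stays open, since the value for compound 3 is a limit: the limit of > 100000 nM in this assay, at which 2 of the 3 values shown sit.

From the compounds shown here alone, whether a longer chain or a chain ending in an amine on this nitrogen would act like methyl remains open. So does whether methyl here would make any difference alongside hydroxy instead of nitro.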